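Triazole thioether oximes: allyl to phenyl on the ring nitrogen

A few compounds are considered here, and "the series" means these few. Any claim that something is new, unique, unknown or untested is made for them only; others in the source may bear on it.

Measured so far:
compound 1 `COc1ccc(-c2nnc(SC/C(=N/O)c3ccccc3)n2-c2ccccc2)cc1` — 58%
compound 2 `C=CCn1c(SC/C(=N/O)c2ccccc2)nnc1-c1ccc(OC)cc1` — 61%
compound 3 `C=CCn1c(SC/C(=N/O)c2ccccc2)nnc1-c1cc(OC)c(OC)c(OC)c1` — 61%

All three compounds were run in a functional assay on the whole organism (strain albino) for inhibition, with Rattus norvegicus as the target, read by paw edema, with a stated time of 1 h, at a dose of 0.28 mmol/kg by the oral route; on this read-out higher numbers stand for more inhibition at the one dose given (going by the name of the read-out) and lower numbers for less inhibition. Compound 1 gives 58% in this assay, compound 2 gives 61%, and compound 3 gives 61%. The three numbers sit within the scatter of one another, so no order among them is claimed.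

Compound 1 and compound 2 differ in one place, (phenyl in place of allyl on an aromatic nitrogen). The step this made in this assay is a number 3 percentage points lower from compound 2 to compound 1 (within the scatter), within the scatter. Compound 2 and compound 3 differ in more than one place; the difference between the two cores is not broken down here.

Compound 4 `COc1cc(-c2nnc(SC/C(=N/O)c3ccccc3)n2-c2ccccc2)cc(OC)c1OC` has not yet been measured. It stands to compound 3 as compound 1 stands to compound 2: phenyl in place of allyl on an aromatic nitrogen. This is the same kind of change, not the same: in compound 2 the aromatic nitrogen is next to the ring atom that bears a 4-methoxyphenyl group and next to the ring atom that bears a large group, whereas in compound 3 it is next to two ring atoms that each bear a large group.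

Given that the one observed instance, a number 3 percentage points lower from compound 2 to compound 1 (within the scatter), was within the scatter, a step of about the same size is expected from compound 3 to compound 4, a number 2 percentage points lower from compound 3 to compound 4 (within the scatter). Compound 4 is therefore estimated at 59% in this assay, expected to lie between 48% and 70%.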

Compound 4, a percentage reported as inhibition, in the whole organism at one dose (the size of the read-out at that dose, not a potency): 61%
For compound 4 the middle estimate is 2 percentage points below the measured one, and the stated range covers the measured number.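

In this assay, phenyl in place of allyl on an aromatic nitrogen now has a second reading, no change at the digits printed from compound 3 to compound 4 (within the scatter), and the two readings do not differ: the same change on two cores in this assay, a number 3 percentage points lower (within the scatter) from compound 2 to compound 1 and no change at the digits printed (within the scatter) from compound 3 to compound 4, 3 percentage points apart, within the scatter of two such steps. On the core of compound 1 and the core of compound 3, the change therefore behaves alike, and neither step stands clear of the scatter. This does not show that the group on this nitrogen is irrelevant to the series or that the change would carry to other cores, since the evidence is two pairs read at a single dose and a single time, which gives the size of the inhibition and not a potency.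

The ring nitrogen carries only allyl or phenyl in the compounds shown, so the response to a longer chain or an amine at that place remains open. Also open is how the read-out would respond if a carboxylic acid took the place of the oxime, which all the compounds shown retain.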